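The compounds below may be only part of what the source reports. "The series", "measured", "known", "first", "only" and "open" are said of these compounds alone.

Measured compounds in a functional assay on PC-3 cells (Homo sapiens) for antiproliferative activity, read by MTT assay, with a stated time of 48 h; on this read-out higher numbers stand for weaker inhibition and lower numbers for stronger inhibition:
compound 1, `COc1cc(N(Cc2ccccc2)C(=O)CSc2nc3ccccc3s2)cc(OC)c1OC`: compound 1 gives 54100 nM
compound 2, `COc1ccc(CN(C(=O)CSc2nc3ccccc3s2)c2cc(OC)c(OC)c(OC)c2)cc1F`: compound 2 gives 20100 nM
compound 3, `COc1ccc(CN(C(=O)CSc2nc3ccccc3s2)c2cc(OC)c(OC)c(OC)c2)cc1N`: compound 3 gives 7510 nM

Compound 3 stands lowest of the three numbers in this assay. Its nearest neighbour is compound 2, with a 2.7-fold lower number from compound 2 to compound 3 (0.43 log units; beyond the scatter); furthest is compound 1, with a 7.2-fold lower number from compound 1 to compound 3 (0.86 log units; beyond the scatter).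

Compound 4, `COc1cc(N(Cc2ccc(Br)cc2)C(=O)CSc2nc3ccccc3s2)cc(OC)c1OC`, is not yet measured. Its change from compound 3: 4-bromophenyl in place of 3-amino-4-methoxyphenyl on a saturated chain carbon bound to an amide-type nitrogen.

All three measured steps bear on this change. Two of them replace plain phenyl on the same saturated chain carbon with a substituted phenyl: a 2.7-fold lower number from compound 1 to compound 2 (0.43 log units; beyond the scatter) and a 7.2-fold lower number from compound 1 to compound 3 (0.86 log units; beyond the scatter). The third swaps one substituent for another on that ring: a 2.7-fold lower number from compound 2 to compound 3 (0.43 log units; beyond the scatter). In every case the lower number came with a ring carrying methoxy, and the lowest with methoxy plus amino. Compound 4 carries neither, only bromine, so the nearest reference is compound 1, which with unsubstituted phenyl gives 54100 nM. The number for compound 4 is therefore expected to move back up from compound 3, by a step estimated at a 4.3-fold higher number from compound 3 to compound 4 (0.63 log units; beyond the scatter), beyond the scatter.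

Compound 4 is estimated at 32000 nM, with a range of 11000 nM to 95000 nM.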

Compound 4, half-maximal inhibitory concentration: > 80000 nM
Compound 4: only a limit was reported; the forecaster's own chance of this, stated with the estimate: 10%; at least 2.5-fold (0.39 log units) between middle value and limit.
By their numbers in this assay, from the lowest: compound 3; then compound 2; then compound 1. At a limit, above all of these: compound 4.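

In this assay compound 4 gives > 80000 nM, which is a limit of the assay and not a number. Substitution on the ring at this position does not by itself lower the number: the earlier substituted rings both did so, whereas 4-bromophenyl gives an at least 10-fold higher number from compound 3 to compound 4 (1.02 log units; beyond the scatter) and an at least 3.9-fold higher number from compound 2 to compound 4 (0.59 log units; beyond the scatter), so the gain in this series so far goes only with the 3-fluoro-4-methoxyphenyl and 3-amino-4-methoxyphenyl rings. Against plain phenyl, bromo in place of hydrogen gives an at least 1.4-fold higher number from compound 1 to compound 4 (0.16 log units; that floor lies within the scatter), and since that floor lies within the scatter, the step shows no lowering but does not establish a rise either.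

The compounds shown do not separate the methoxy group from the amino or fluoro group, so a 4-methoxyphenyl or a 3-aminophenyl ring on the same saturated chain carbon would be needed to tell which of them goes with the lower numbers. Also open, on these data alone, is whether bromine itself carries the loss, which a 3-bromo-4-methoxyphenyl ring at this position would address.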